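The source may report more compounds than this note shows. Statements on the series, on what has been measured and on what is new or still open speak of the compounds shown alone.

Compound 1 `CN(O)C(=O)C1=Cc2ccccc2OC1` gives 830 nM
Compound 2 `NC(=O)N(O)CC1=Cc2cc(OCc3ccc(C(F)(F)F)cc3)ccc2OC1` gives 430 nM
Compound 3 `CCCCCCOc1ccc2c(c1)C=C(CN(O)C(N)=O)CO2` gives 280 nM

These three compounds were tested in an assay (Cavia porcellus) for inhibition of Polyunsaturated fatty acid 5-lipoxygenase (Homo sapiens); a lower number here means a stronger inhibitor, a higher number a weaker inhibitor. Compound 3 shows the lowest of the three numbers. Its gap to compound 1 lies beyond the usual scatter, so compound 3 reads as the stronger inhibitor of that pair; its gap to compound 2, however, lies within the scatter, so the two cannot be told apart on these data.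

Compound 4 `NC(=O)N(O)CC1=Cc2cc(OCCCc3ccccc3)ccc2OC1` has not yet been measured in this assay. It is compound 3 with one change: phenyl in place of propyl on a saturated chain carbon, three bonds along the chain from an oxygen on an aromatic ring. Within the data shown here, no measured pair here differs in just this way, so the step has to be judged from the neighbourhood. Compound 2, which carries an aromatic ring on its ether chain, sits within the scatter of compound 3, which carries a plain chain; on that footing the expected step of a 1.1-fold higher number from compound 3 to compound 4 (0.03 log units; within the scatter) is none beyond the scatter. Compound 4 is therefore estimated at 300 nM, with a range from 120 nM to 750 nM.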

Compound 4, half-maximal inhibitory concentration: 130 nM
Estimate against measurement, compound 4: 2.3-fold (0.36 log units) above, within the range that was stated.
By their numbers in this assay, from the lowest: compound 4; then compounds 3, 2 and 1 (each within the scatter of the next, the first and the last beyond it).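

Among these compounds, compounds 3 and 4 form the first pair here that differs in one place, so the effect of this change can now be read directly. In this assay, the swap of propyl for phenyl gives a 2.2-fold lower number from compound 3 to compound 4 (0.33 log units; beyond the scatter), a modest step, which shows that this end of the ether chain accepts a six-membered aromatic ring and that the ring gives a stronger inhibitor than the plain chain end. Nothing available explains why the number moves.

As far as these compounds go, whether the aromatic ring itself matters or the extra carbons alone would do remains open, and a cyclohexyl group in the same place would help separate the two. Also open, from the compounds shown here alone, is how an amine or a carboxylic acid on the phenyl ring, or a longer chain leading to it, would read in this assay.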